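The compounds below may be only part of what the source reports. "The series", "measured", "known", "first", "only" and "open" are said of these compounds alone.

Measured in a functional assay on HepG2 cells (Homo sapiens) for antiproliferative activity, read by MTT assay, with a stated time of 48 h; a higher number here means a weaker inhibitor, a lower number a stronger inhibitor:
compound 1 `COc1ccc(NC(=O)Nc2cccc(CNc3nccnc3Cl)c2)cc1` gives 12000 nM;
compound 3 `Cc1ccc(NC(=O)Nc2cccc(CNc3nccnc3Cl)c2)c(C)c1` gives 9290 nM.

Compound 2 `CN(C)c1ccc(NC(=O)Nc2cccc(CNc3nccnc3Cl)c2)cc1` gives only a limit of the assay, > 40000 nM. Compound 2 therefore stands at the limit of > 40000 nM in this assay, at which 1 of the 3 values shown sits, with no number of its own. Compound 4 `O=C(Nc1cccc(CNc2nccnc2Cl)c1)NC1CCCC1` carries the change (cyclopentyl in place of 4-(dimethylamino)phenyl on an amide-type nitrogen). The measured steps that alter the same group are an at least 3.3-fold higher number from compound 1 to compound 2 (0.52 log units; beyond the scatter) and an at least 4.3-fold lower number from compound 2 to compound 3 (0.63 log units; beyond the scatter); in both, compound 2 gives the higher number beyond the scatter, while a 1.3-fold lower number from compound 1 to compound 3 (0.11 log units; within the scatter) stays within it. Among the compounds with values here, no measured step brings in a non-aromatic ring, so the size is uncertain, but a drop from the limit is expected for compound 4, an at least 2.6-fold lower number from compound 2 to compound 4 (0.42 log units; beyond the scatter). Compound 4 is estimated at 15000 nM, between 5000 nM and 45000 nM.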

Compound 4, half-maximal inhibitory concentration: 18400 nM
Estimate against measurement, compound 4: 1.2-fold (0.09 log units) below, and the stated range covers the measured number.
By their numbers in this assay, from the lowest: compounds 3, 1 and 4 (each within the scatter of the next). At a limit, above all of these: compound 2.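

In this assay, a non-aromatic ring on the amide-type nitrogen holds up: the change to cyclopentyl gives an at least 2.1-fold lower number from compound 2 to compound 4 (0.33 log units; beyond the scatter). That step starts from a limit, not a number: the limit of > 40000 nM in this assay, at which 1 of the 4 values shown sits. Cyclopentyl also stands level with the 4-methoxyphenyl and 2,4-dimethylphenyl groups, with a 2.0-fold higher number from compound 3 to compound 4 (0.30 log units; within the scatter) and a 1.5-fold higher number from compound 1 to compound 4 (0.19 log units; within the scatter), so an aromatic ring is not required here for this level of activity.

Still open, as far as these compounds go, is whether ring size matters, as a cyclohexyl group would show. Also open, from the compounds shown here alone, is whether any ring is needed, as an open butyl chain would show.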